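The source may hold more compounds than are shown below. What is called first, only, known or untested is meant among the compounds shown, and "the series" means these compounds.

Compound 1 `CN(c1cccc2c1CN(c1nc(Nc3cccc(Oc4ccccc4)c3)ncc1C(F)(F)F)C2)S(C)(=O)=O` gives 23000 nM
Compound 2 `Cc1cc(Cl)ccc1Nc1ncc(C(F)(F)F)c(N2Cc3cccc(N(C)S(C)(=O)=O)c3C2)n1` gives 19600 nM
Compound 3 `COc1cc(Nc2ncc(C(F)(F)F)c(N3Cc4cccc(N(C)S(C)(=O)=O)c4C3)n2)cc(C(F)(F)F)c1` gives 22100 nM

These values come from a functional assay on HepG2 cells (Homo sapiens) for antiproliferative activity, read by spectrophotometry, with a stated time of 2 days; a higher number here means a weaker inhibitor of growth, a lower number a stronger inhibitor of growth. Compound 3 lies within the scatter of both compound 1 and compound 2, so the three cannot be ranked. Compound 4 `CN(c1cccc2c1CN(c1nc(Nc3cccc(C(F)(F)F)c3)ncc1C(F)(F)F)C2)S(C)(=O)=O` is compound 3 with one change: hydrogen in place of methoxy on an aromatic carbon. Among the compounds with values here, the one measured step that bears on it is a 1.1-fold higher number from compound 2 to compound 3 (0.05 log units; within the scatter), so no step beyond the scatter is expected in this assay. That step exchanged a whole substituted phenyl group, so it does not test methoxy alone, and the expectation stays loose. The expected step is a 1.1-fold lower number from compound 3 to compound 4 (0.02 log units; within the scatter). For compound 4 the estimate is 21000 nM, with an expected range of 12000 nM to 36000 nM.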

Compound 4, concentration for 50% growth inhibition: > 30000 nM
Compound 4 gave a limit, no number (the forecaster's own chance of this, stated with the estimate: 10%); middle value at least 1.4-fold (0.15 log units) from the limit.
By their numbers in this assay, from the lowest: compounds 2, 3 and 1 (each within the scatter of the next). At a limit, above all of these: compound 4.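

Swapping methoxy for hydrogen on this aromatic carbon, meta to a trifluoromethyl group, leaves compound 4 at > 30000 nM in this assay, which is a limit of the assay and not a number. The steps it gives are therefore only floors: an at least 1.3-fold higher number from compound 3 to compound 4 (0.13 log units; that floor lies within the scatter), an at least 1.5-fold higher number from compound 2 to compound 4 (0.18 log units; that floor lies within the scatter), and an at least 1.3-fold higher number from compound 1 to compound 4 (0.11 log units; that floor lies within the scatter). Hydrogen here brings no gain in growth inhibition, but whether it brings a real loss cannot be said.

Still open, going by these compounds, is how far compound 4 truly lies from the others. Also open, on these data alone, is whether an amine or a carboxylic acid at this position would shift the number beyond the scatter.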